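Hydroxy on the aromatic ring of compound 2

The compounds below may be only part of what the source reports. "The series", "measured", "known", "first", "only" and "open" are said of these compounds alone.

Compound 1 `COc1ccc(C[C@H]2C(=O)N[C@@H](C)C(=O)N(C)[C@H]3Cc4ccc(cc4)Oc4cc(ccc4OC)C[C@@H](C(=O)N[C@H](C)C(=O)N[C@@H](CC=O)C(=O)N2C)N(C)C3=O)cc1` gives 33.9 nM in a functional assay on P388 cells (Mus musculus) for cytotoxicity (a higher number here means a weaker inhibitor, a lower number a stronger inhibitor), and compound 2 `C[C@@H]1NC(=O)[C@@H](C)NC(=O)[C@@H]2Cc3cccc(c3)Oc3ccc(cc3)C[C@@H](C(=O)N2C)N(C)C(=O)[C@H](C)NC(=O)[C@H](Cc2ccccc2)N(C)C1=O` gives 525 nM as the higher of the two numbers, a gap beyond the scatter. Compound 3 `C[C@@H]1NC(=O)[C@@H](C)NC(=O)[C@@H]2Cc3ccc(O)c(c3)Oc3ccc(cc3)C[C@@H](C(=O)N2C)N(C)C(=O)[C@H](C)NC(=O)[C@H](Cc2ccccc2)N(C)C1=O` carries hydroxy in place of hydrogen on an aromatic carbon of compound 2 hydroxy in place of hydrogen on an aromatic carbon and differs in nothing else. Among the compounds with values here, no measured pair shows this change, so the expectation is loose. A moderate fall in the number in this assay is expected, with the estimated change a 3.1-fold lower number from compound 2 to compound 3 (0.49 log units; beyond the scatter) as the working figure. For compound 3 the estimate is 170 nM as the middle, within an expected range of 40 nM to 600 nM for now.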

Compound 3, half-maximal inhibitory concentration: 42.7 nM
Estimate against measurement, compound 3: 4.0-fold (0.60 log units) above, and the stated range covers the measured number.
By their numbers in this assay, from the lowest: compounds 1 and 3 (each within the scatter of the next); then compound 2.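

In this assay, placing hydroxy on this aromatic carbon, ortho to a fused ring and para to a fused ring, gives a 12-fold lower number from compound 2 to compound 3 (1.09 log units; beyond the scatter), the first single-place change read in the series. This position is therefore not indifferent to substitution: a single added oxygen moves the number beyond the scatter. Nothing available accounts for the size of this step.

Only hydrogen and hydroxy can be compared at this carbon. Going by these compounds, whether an amine, a fluorine atom or a carboxylic acid there would match hydroxy remains open, as does the effect of the same change on other members.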